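Fluorine Pattern on the Aryl Ether of Compound 3

The source may hold more compounds than are shown below. What is called first, only, known or untested is meant among the compounds shown, and "the series" means these compounds.

In a functional assay with Homo sapiens as the target (on this read-out lower numbers stand for stronger inhibition and higher numbers for weaker inhibition), compound 1 `CC(C)[C@H](NC(=O)COc1cccc2ccccc12)C(=O)N[C@@H](CC(=O)O)C(=O)COC(=O)c1c(Cl)cccc1Cl` gives 11500 nM. In this assay compound 2 `CC(C)[C@H](NC(=O)COc1cccc2ccccc12)C(=O)N[C@@H](CC(=O)O)C(=O)COc1ccccc1C(F)(F)F` gives 17300 nM, and the step between them is a 1.5-fold higher number from compound 1 to compound 2 (0.18 log units; within the scatter). Compound 3 `CC(C)[C@H](NC(=O)COc1cccc2ccccc12)C(=O)N[C@@H](CC(=O)O)C(=O)COc1c(F)cccc1F` stands at > 100000 nM, which is a limit of the assay and not a number. Compound 4 `CC(C)[C@H](NC(=O)COc1cccc2ccccc12)C(=O)N[C@@H](CC(=O)O)C(=O)COc1cc(F)cc(F)c1F` differs from it by 2,3,5-trifluorophenyl in place of 2,6-difluorophenyl on an oxygen on a saturated carbon, with 2,3,5-trifluorophenyl in place of 2,6-difluorophenyl. Going by the values given here, two measured steps bear on this group: an at least 8.6-fold higher number from compound 1 to compound 3 (0.93 log units; beyond the scatter) and an at least 5.7-fold higher number from compound 2 to compound 3 (0.76 log units; beyond the scatter). Among the compounds with values here, a step of similar size in the opposite direction, towards a lower number, is therefore expected, though no measured step shows this exact change. The expected step is an at least 3.3-fold lower number from compound 3 to compound 4 (0.52 log units; beyond the scatter). For compound 4 the estimated value is 30000 nM, with an expected range of 8000 nM to 90000 nM.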

Compound 4, half-maximal inhibitory concentration: 11200 nM
The estimate for compound 4 lay 2.7-fold (0.43 log units) above the measured number, within the range that was stated.
By their numbers in this assay, from the lowest: compounds 4, 1 and 2 (each within the scatter of the next). At a limit, above all of these: compound 3.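

In this assay, 2,3,5-trifluorophenyl in place of 2,6-difluorophenyl on this oxygen gives an at least 8.9-fold lower number from compound 3 to compound 4 (0.95 log units; beyond the scatter), so the loss seen with compound 3 belongs to that one fluorine pattern and not to fluorinated phenyl ethers as a whole. The new group cannot be told apart from the two earlier groups, with a 1.5-fold lower number from compound 2 to compound 4 (0.19 log units; within the scatter) and a 1.0-fold lower number from compound 1 to compound 4 (0.01 log units; within the scatter). Compound 3 stands at a limit of the assay and not at a number, so the true size of its step stays unknown: the limit of > 100000 nM in this assay, at which 1 of the 4 values shown sits.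

Which of the three fluorines of compound 4 accounts for the difference from compound 3 stays open. So does whether a single fluorine, a nitrile or an amine on this phenyl ring would give a similar number.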